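This account rests on a few compounds, and the source may have more. Where it says the series, first, only, none or still open, it means among the compounds named here.

The comparison rests on a toxicity assay on MDCK cells (Canis lupus familiaris) for cytotoxicity, read by crystal violet staining, with a stated time of 48 h (on this read-out higher numbers stand for lower toxicity in this test and lower numbers for higher toxicity in this test), in which two compounds have so far been tested. Compound 1, `CCc1ccc2[nH]c(=O)c(CN(Cc3ccc(F)cc3)Cc3ccc(-c4ccccc4)cc3)cc2c1`, gives > 5000 nM in this assay, which is a limit of the assay rather than a number. Compound 2, `Cc1ccc2[nH]c(=O)c(CN(Cc3ccc(F)cc3)Cc3cccc4ccccc34)cc2c1`, gives > 5000 nM in this assay, again a limit rather than a measured number. Compound 2 therefore stands at the limit, and no measured number places it anywhere else among the values shown. Compound 3, `CCc1ccc2[nH]c(=O)c(CN(Cc3ccc(F)cc3)Cc3cccc4ccccc34)cc2c1`, has yet to be tested in this assay. It differs from compound 2 by methyl in place of hydrogen on a saturated chain carbon bound to an aromatic carbon, joining the core of compound 1 with the rest of compound 2. Within the data shown here, no step between two measured compounds is available. Because the limit of > 5000 nM in this assay, at which 2 of the 2 values shown sit, holds for every value shown, no movement beyond the scatter is expected in this assay, and another limit is the most likely outcome. The expected step from compound 2 to compound 3 in this assay is a step that the limit leaves unreadable from compound 2 to compound 3. Compound 3 is expected to give about 8000 nM in this assay, within a range from 4000 nM to 20000 nM.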

Compound 3, half-maximal cytotoxic concentration: > 5000 nM
Compound 3: only a limit was reported; the forecaster's own chance of this, stated with the estimate: 85%; the middle value lies beyond the limit too.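

No step can be read from compound 2 to compound 3 or from compound 1 to compound 3, since each value is a limit rather than a number: the limit of > 5000 nM in this assay, at which 3 of the 3 values shown sit.

The compounds shown leave open how toxic each one actually is in this assay, and whether either structural change alters that toxicity at all.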